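The compounds below may be only part of what the source reports. "The series", "measured", "known", "first", "only" and "open" are said of these compounds alone.

Measured so far:
- Compound 1, `CN1C(=O)N(c2ccccc2)C2NC(=S)N(/N=C/C=C/c3ccccc3)C21`: 167000 nM
- Compound 2, `COc1ccccc1/C=C/C=N/N1C(=S)NC2C1N(C)C(=O)N2c1ccccc1`: 230 nM

In an ADME assay on HEK293 cells (Homo sapiens) for inhibition, read by MTT assay, with a stated time of 72 h (a higher number here means a weaker inhibitor, a lower number a stronger inhibitor), compound 2 gives 230 nM, the lowest of the two numbers. Within the data shown here, its nearest neighbour is compound 1, which gives 167000 nM; the step of a 730-fold lower number from compound 1 to compound 2 (2.86 log units; beyond the scatter) is the only measured step in this set.

Compound 3, `CCN1C(=O)N(c2ccccc2)C2NC(=S)N(/N=C/C=C/c3ccccc3OC)C21`, has not yet been measured in this assay. It differs from compound 2 by methyl in place of hydrogen on a saturated chain carbon bound to an amide-type nitrogen in a ring, which read one bond further out is methyl to ethyl. Among the measured compounds shown here, the one measured step, a 730-fold lower number from compound 1 to compound 2 (2.86 log units; beyond the scatter), concerns a methoxy group on an aromatic ring and so does not bear on a change at the chain carbon bound to the amide-type nitrogen. With no measured comparison for this kind of change, the expectation is a step of a 1.3-fold higher number from compound 2 to compound 3 (0.12 log units; within the scatter) in this assay, which is to say nothing beyond the usual scatter, with the direction left open. Compound 3 is therefore estimated at 300 nM, within a range from 100 nM to 1000 nM.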

Compound 3, half-maximal inhibitory concentration: 57500 nM
Compound 3: the middle estimate sits 190-fold (2.28 log units) below what was measured; measured number above the stated range.
By their numbers in this assay, from the lowest: compound 2; then compound 3; then compound 1.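

Methyl in place of hydrogen on a saturated chain carbon bound to an amide-type nitrogen in a ring, which turns methyl into ethyl, adds only one heavy atom, yet in this assay it gives a 250-fold higher number from compound 2 to compound 3 (2.40 log units; beyond the scatter). Among these compounds, the earlier pair said nothing about this position, since its only step, a 730-fold lower number from compound 1 to compound 2 (2.86 log units; beyond the scatter), came from a methoxy group on an aromatic carbon, and the new result shows that this second site is also highly sensitive, with a large step beyond the scatter from a very small edit. Nothing measured here explains why so small a change has so large an effect.

The compounds shown leave open whether a longer chain, such as propyl, or a chain carrying an amine or a carboxylic acid would move the number further in the same direction or bring it back. They also leave open whether the same methyl to ethyl change would have a step of similar size on a compound without the methoxy group, so the two changes cannot yet be treated as independent of each other.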